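Swapping a Diethylamino Tail for a Methylpiperazinyl Chain

The source may hold more compounds than are shown below. What is called first, only, known or untested is meant among the compounds shown, and "the series" means these compounds.

Measured in a functional assay on B16 cells (Mus musculus) for cytotoxicity, read by MTT assay, with a stated time of 72 h; a lower number here means a stronger inhibitor, a higher number a weaker inhibitor:
Compound 1 `COc1ccccc1-c1cc(=O)c2c(O)cc(OCCCCN3CCN(C)CC3)c(OC)c2o1`: 9300 nM
Compound 2 `COc1c(OCCCCN2CCN(C)CC2)cc(O)c2c(=O)cc(-c3ccc(F)cc3)oc12`: 4320 nM
Compound 3 `CCN(CC)CCCOc1c(OCc2ccccc2)cc(O)c2c(=O)cc(-c3ccccc3)oc12`: 4900 nM

Compound 3 stands second highest of the three numbers. Compound 2 is its nearest neighbour, within the scatter, and compound 1 its furthest, also within the scatter. Within the data shown here, the only step between compounds differing in one place is a 2.2-fold lower number from compound 1 to compound 2 (0.33 log units; beyond the scatter); it concerns the aryl group on the shared core, not the amine-bearing chain.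

Compound 4 `CN1CCN(CCCCOc2c(OCc3ccccc3)cc(O)c3c(=O)cc(-c4ccccc4)oc23)CC1` differs from compound 3 by (4-methylpiperazin-1-yl)methyl in place of diethylamino on a saturated chain carbon, three bonds along the chain from an oxygen on an aromatic ring. Among the measured compounds shown here, no measured step addresses this change directly. Compound 1 and compound 2 each carry the chain that enters in compound 4, and each lies within the scatter of compound 3 in this assay, so nothing in the data points to a shift in either direction. Compound 4 is therefore expected to show a 1.1-fold higher number from compound 3 to compound 4 (0.05 log units; within the scatter), no step beyond the scatter. The estimate for compound 4 is 5500 nM, with a range from 2000 nM to 15000 nM.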

Compound 4, half-maximal inhibitory concentration: 2370 nM
Compound 4: the middle estimate sits 2.3-fold (0.37 log units) above what was measured; low and high end bracket the measured number.
By their numbers in this assay, from the lowest: compounds 4, 2, 3 and 1 (each within the scatter of the next, the first and the last beyond it).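

In this assay, the chain carrying the amine proves to be a place where a change can move the number beyond the scatter: a 2.1-fold lower number from compound 3 to compound 4 (0.32 log units; beyond the scatter). Among these compounds, the only earlier step concerned the aryl group on the shared core, so this is the first reading of the chain itself. Read one bond further out, the change is 3-(diethylamino)propyl to 4-(4-methylpiperazin-1-yl)butyl, so the step carries the amine and the chain length together, and nothing available explains it.

The compounds shown do not separate those two parts, since they include neither a 3-(4-methylpiperazin-1-yl)propyl nor a 4-(diethylamino)butyl chain. From the compounds shown here alone, how a morpholine ring at the end of the same chain would compare also remains open.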